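A few compounds are considered here, and "the series" means these few. Any claim that something is new, unique, unknown or untested is made for them only; others in the source may bear on it.

For the measured compounds named here, the three compounds measured so far share one core and differ only in the group carried on an amine nitrogen in a ring. Compound 1 `CCCn1c(=O)[nH]c2nc(-c3ccc(S(=O)(=O)N4CCN(c5ccc(F)cc5)CC4)cc3)[nH]c2c1=O` bears a 4-fluorophenyl there, compound 2 `CCCn1c(=O)[nH]c2nc(-c3ccc(S(=O)(=O)N4CCN(c5ccccc5C)CC4)cc3)[nH]c2c1=O` a 2-methylphenyl, and compound 3 `CCCn1c(=O)[nH]c2nc(-c3ccc(S(=O)(=O)N4CCN(Cc5cccc(Br)c5)CC4)cc3)[nH]c2c1=O` a 3-bromobenzyl. In an assay on CHO cells for displacement of a labelled ligand from adenosine receptor A1 (Homo sapiens), read by scintillation counting, with a stated time of 90 min, in the presence of a further agent that is not named here (on this read-out higher numbers stand for weaker inhibition and lower numbers for stronger inhibition), compound 1 gives only a limit of the assay, > 1000 nM, not a number (the limit of > 1000 nM in this assay, at which 1 of the 3 values shown sits). In this assay compound 2 gives 419 nM. In this assay compound 3 gives 928 nM, the higher of the two real numbers, and the step of a 2.2-fold higher number from compound 2 to compound 3 (0.35 log units; beyond the scatter) lies beyond the scatter. The step of an at least 1.0-fold lower number from compound 1 to compound 3 (0.03 log units; that floor lies within the scatter) has a floor that lies within the scatter.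

Compound 4 `CCCn1c(=O)[nH]c2nc(-c3ccc(S(=O)(=O)N4CCN(c5cccc(Br)c5)CC4)cc3)[nH]c2c1=O` has not yet been measured. Its change from compound 3 is 3-bromophenyl in place of 3-bromobenzyl on an amine nitrogen in a ring. Two measured steps swap a directly attached aromatic ring for a benzyl-type group, though each with a different substituent on that ring: an at least 1.0-fold lower number from compound 1 to compound 3 (0.03 log units; that floor lies within the scatter) and a 2.2-fold higher number from compound 2 to compound 3 (0.35 log units; beyond the scatter). Both point to at most a modest shift when the benzyl is traded back for a directly attached ring, and the second suggests the number may fall. The expected step is a 1.5-fold lower number from compound 3 to compound 4 (0.19 log units; within the scatter). Compound 4 is therefore estimated at 600 nM in this assay, within a range from 250 nM to 1500 nM.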

Compound 4, inhibition constant: > 1000 nM
Compound 4: no number, only a limit; the forecaster's own chance of this, stated with the estimate: 25%; middle value at least 1.6-fold (0.22 log units) away from the limit.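

Compound 4 gives only a limit in this assay, not a number: the limit of > 1000 nM in this assay, at which 2 of the 4 values shown sit.

The step of an at least 1.0-fold higher number from compound 3 to compound 4 (0.03 log units; that floor lies within the scatter) has a floor within the scatter, so the data cannot say whether trading the 3-bromobenzyl for a 3-bromophenyl moves the number at all. The step of an at least 2.3-fold higher number from compound 2 to compound 4 (0.37 log units; beyond the scatter) lies beyond the scatter, which shows that a ring attached directly to the amine nitrogen does not by itself give the level of compound 2; of the three compounds with such a ring, compounds 1, 2 and 4, only compound 2 gives a real number, so the group carried on that ring matters at this position.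

From the compounds shown here alone, the step between compound 1 and compound 4 cannot be read, since both ends are limits, and how far either compound lies past the limit stays unknown. Also open, going by these compounds, is how this position would respond to a plain phenyl, a phenethyl with its longer chain, or a ring carrying an amine or a carboxylic acid.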